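From 3-fluorophenyl to 3-cyanophenyl: a small expected step

The source may hold more compounds than are shown below. What is called first, only, known or untested is meant among the compounds shown, and "the series" means these compounds.

In a toxicity assay on MT4 cells (Homo sapiens) for cytotoxicity, read by MTT assay (a lower number here means that less compound is tolerated, a higher number that more compound is tolerated), compound 3 (`Cc1cc(-c2cccc(F)c2)ccc1Oc1cc(N)nc(Nc2ccc(C#N)cc2)n1`) gives 11300 nM. This lies within the scatter of compound 1 (`Cc1cc(-c2cccc(C#N)c2)cc(C)c1Oc1cc(N)nc(Nc2ccc(C#N)cc2)n1`), which gives 20200 nM, whereas compound 2 (`Cc1cc(-c2ccccc2F)ccc1Oc1cc(N)nc(Nc2ccc(C#N)cc2)n1`) gives 29500 nM, a gap beyond the scatter. Compound 4 (`Cc1cc(-c2cccc(C#N)c2)ccc1Oc1cc(N)nc(Nc2ccc(C#N)cc2)n1`) has cyano in place of fluoro on an aromatic carbon. Among the measured compounds shown here, the one measured step, a 2.6-fold lower number from compound 2 to compound 3 (0.42 log units; beyond the scatter), is modest, but it swaps 2-fluorophenyl for 3-fluorophenyl, not fluoro for cyano. Compound 1 already holds 3-cyanophenyl, with 20200 nM, but its structure also differs elsewhere. No step beyond the scatter is therefore expected in this assay, and the estimated change is a 1.3-fold higher number from compound 3 to compound 4 (0.12 log units; within the scatter). For compound 4 the expected value is 15000 nM, with an estimated range of 6500 nM to 34000 nM.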

Compound 4, half-maximal cytotoxic concentration: 27400 nM
Estimate against measurement, compound 4: 1.8-fold (0.26 log units) below; measured number inside the range.
By their numbers in this assay, from the lowest: compounds 3, 1, 4 and 2 (each within the scatter of the next, the first and the last beyond it).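

In this assay, cyano in place of fluoro on this aromatic carbon gives a step beyond the scatter, a 2.4-fold higher number from compound 3 to compound 4 (0.38 log units; beyond the scatter), so this swap is not as neutral as it looked. Cyano at this position also matches 2-fluorophenyl, a 1.1-fold lower number from compound 2 to compound 4 (0.03 log units; within the scatter), and hydrogen in place of methyl on the other ring changes nothing that can be told from the scatter, a 1.4-fold higher number from compound 1 to compound 4 (0.13 log units; within the scatter). No measurement here explains the shift. From the compounds shown here alone, whether an amine or a carboxylic acid on this carbon would move the number further remains open, and this fluoro-to-cyano effect rests on a single pair.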